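Phenyl for Methyl on a Sulfonamide Nitrogen

A few compounds are considered here, and "the series" means these few. Any claim that something is new, unique, unknown or untested is made for them only; others in the source may bear on it.

Compound 1 `CCCNS(=O)(=O)c1cncc(-c2ccn3nc(N)nc3c2)c1` — 31600000 nM
Compound 2 `CNS(=O)(=O)c1cncc(-c2ccn3nc(N)nc3c2)c1` — 39800000 nM
Compound 3 `Nc1nc2cc(-c3cncc(S(=O)(=O)Nc4ccccc4)c3)ccn2n1` — not yet measured

Among the measured compounds shown here, in an assay on isolated protein for inhibition of phosphatidylinositol 4,5-bisphosphate 3-kinase catalytic subunit beta isoform (Homo sapiens) (on this read-out higher numbers stand for weaker inhibition and lower numbers for stronger inhibition), compound 2 gives 39800000 nM, and its only neighbour compound 1 gives 31600000 nM, a gap that is a 1.3-fold higher number from compound 1 to compound 2 (0.10 log units; within the scatter). Compound 3 carries phenyl in place of methyl on a sulfonamide nitrogen. For the measured compounds named here, the one measured step also altered the group on this sulfonamide nitrogen and stayed within the scatter, but no measured step covers a ring entering there. With both known numbers very high and close together, the expected change is no step beyond the scatter, a 1.1-fold lower number from compound 2 to compound 3 (0.06 log units; within the scatter). Compound 3 is therefore estimated at 35000000 nM, with a range from 9000000 nM to 140000000 nM.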

Compound 3, half-maximal inhibitory concentration: 31600000 nM
For compound 3 the middle estimate is 1.1-fold (0.04 log units) above the measured one, and the stated range covers the measured number.
By their numbers in this assay, from the lowest: compounds 1, 3 and 2 (each within the scatter of the next).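

In this assay, the first ring on the sulfonamide nitrogen reads like the chains: phenyl in place of methyl gives a 1.3-fold lower number from compound 2 to compound 3 (0.10 log units; within the scatter), and phenyl in place of propyl gives no change at the digits printed from compound 1 to compound 3 (within the scatter). Methyl, propyl and phenyl at this place therefore all lie within the scatter of one another, even with a six-membered aromatic ring entering. Nothing available explains this sameness. Still open, as far as these compounds go, is whether an amine or a carboxylic acid carried on this nitrogen would give a step beyond the scatter.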